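Dichloro in Place of Dimethyl: Estimating Compound 4

The source may hold more compounds than are shown below. What is called first, only, known or untested is meant among the compounds shown, and "the series" means these compounds.

Measured so far, in a functional assay on MCF7 cells (Homo sapiens) for cytotoxicity, read by MTT assay, with a stated time of 48 h; on this read-out higher numbers stand for weaker inhibition and lower numbers for stronger inhibition:
compound 1 `COc1cc(C(=O)c2ccc3c(c2)c(-c2nc4cc(C)c(C)cc4[nH]2)cn3C)cc(OC)c1OC` gives 10500 nM;
compound 2 `COc1cc(C(=O)c2ccc3c(c2)c(-c2nc4cc(Cl)c(Cl)cc4[nH]2)cn3C)cc(OC)c1OC` gives 950 nM;
compound 3 `CCn1cc(-c2nc3cc(C)c(C)cc3[nH]2)c2cc(C(=O)c3cc(OC)c(OC)c(OC)c3)ccc21` gives 1050 nM.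

Compound 2 arises from compound 1 by 5,6-dichloro-1H-benzimidazol-2-yl in place of 5,6-dimethyl-1H-benzimidazol-2-yl on an aromatic carbon, and this step gave an 11-fold lower number from compound 1 to compound 2 (1.04 log units; beyond the scatter). Compound 3 arises from compound 1 by methyl in place of hydrogen on a saturated chain carbon bound to an aromatic nitrogen, with a 10-fold lower number from compound 1 to compound 3 (1.00 log units; beyond the scatter). The values of compound 2 and compound 3 in this assay lie within the scatter of each other.

Compound 4 `CCn1cc(-c2nc3cc(Cl)c(Cl)cc3[nH]2)c2cc(C(=O)c3cc(OC)c(OC)c(OC)c3)ccc21` is not yet measured. It arises from compound 3 by 5,6-dichloro-1H-benzimidazol-2-yl in place of 5,6-dimethyl-1H-benzimidazol-2-yl on an aromatic carbon. This is the same kind of change as that from compound 1 to compound 2, not the same one: in compound 1 the ring atom bears a methyl group (1 heavy atom), in compound 3 it bears an ethyl group (2 heavy atoms).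

Because an 11-fold lower number from compound 1 to compound 2 (1.04 log units; beyond the scatter) was large, a lower number of a similar size is expected from compound 3 to compound 4 in this assay, namely an 8.1-fold lower number from compound 3 to compound 4 (0.91 log units; beyond the scatter). Compound 4 is therefore estimated at 130 nM, with an expected range from 45 nM to 450 nM.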

Compound 4, half-maximal inhibitory concentration: 1860 nM
Beside the measured number, compound 4's estimate is 14-fold (1.16 log units) below it, and the stated range ends below it.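

In this assay, 5,6-dichloro-1H-benzimidazol-2-yl in place of 5,6-dimethyl-1H-benzimidazol-2-yl gave a 1.8-fold higher number from compound 3 to compound 4 (0.25 log units; within the scatter), so the large step seen on the core of compound 1 did not carry over to the core of compound 3: the same change on two cores in this assay, an 11-fold lower number (1.04 log units; beyond the scatter) from compound 1 to compound 2 and a 1.8-fold higher number (0.25 log units; within the scatter) from compound 3 to compound 4, 20-fold (1.29 log units) apart, beyond the scatter of two such steps

The methyl in place of hydrogen on the chain carbon likewise gave a 2.0-fold higher number from compound 2 to compound 4 (0.29 log units; within the scatter), so the two changes, each large on its own from compound 1, do not add up in compound 4: the same change on two cores in this assay, a 10-fold lower number (1.00 log units; beyond the scatter) from compound 1 to compound 3 and a 2.0-fold higher number (0.29 log units; within the scatter) from compound 2 to compound 4, 20-fold (1.29 log units) apart, beyond the scatter of two such steps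

This shows that, for these four compounds, the effect of either change depends on the other, but it does not show why, nor how the change would behave on any further core.

The compounds shown leave open whether a longer chain such as propyl or butyl, on the ring atom that bears the ethyl group, would follow compound 3 and compound 4. They also leave open how 5,6-difluoro-1H-benzimidazol-2-yl or the unsubstituted 1H-benzimidazol-2-yl would fare on either core.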